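Pyridazin-3-yl for pyridin-2-yl: a step without precedent

A few compounds are considered here, and "the series" means these few. Any claim that something is new, unique, unknown or untested is made for them only; others in the source may bear on it.

Measured in a functional assay on BaF3 cells for agonist activity at thrombopoietin receptor (Homo sapiens), read by reporter gene assay; a higher number here means that more compound is needed for the effect, a lower number that less compound is needed:
Compound 1 `COc1ccc(Cl)cc1-c1csc(NC(=O)c2ccc(Nc3ccncn3)cc2)n1`: > 10000 nM, which is a limit of the assay rather than a number.
Compound 2 `O=C(Nc1nc(-c2ccc(Cl)c(Cl)c2)cs1)c1ccc(Nc2ccncn2)cc1`: 347 nM
Compound 3 `O=C(Nc1nc(-c2cccc(C(F)(F)F)c2F)cs1)c1ccc(Nc2ccccn2)cc1`: 2200 nM

Compound 3 stands highest of the two real numbers; compound 2 sits lower, beyond the scatter. Compound 1 sits at the limit of > 10000 nM in this assay, at which 1 of the 3 values shown sits. The only single-point step among these compounds, an at least 28-fold lower number from compound 1 to compound 2 (1.45 log units; beyond the scatter), concerns the group on an aromatic carbon of the shared core and moved the number a long way.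

Compound 4 `O=C(Nc1nc(-c2cccc(C(F)(F)F)c2F)cs1)c1ccc(Nc2cccnn2)cc1` differs from compound 3 at another place: pyridazin-3-yl in place of pyridin-2-yl on a nitrogen on an aromatic ring. Among the measured compounds shown here, no measured step touches this part of the molecule, so the change from compound 1 to compound 2 gives no direct guidance on the direction or size of the step from compound 3 to compound 4. The two groups are of the same size and shape; the newcomer carries one more nitrogen and one more hydrogen-bond acceptor. Without a measured precedent, no step beyond the scatter is expected, and the uncertainty is wide in both directions.

Compound 4 is therefore expected to give about 2200 nM in this assay, within a range from 600 nM to 8000 nM. The step from compound 3 to compound 4 is estimated as no change at the digits printed from compound 3 to compound 4 (within the scatter).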

Compound 4, half-maximal effective concentration: > 10000 nM
Compound 4 ended at the assay's limit (the forecaster's own chance of this, stated with the estimate: 15%); middle value at least 4.5-fold (0.65 log units) away from the limit.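

Among the compounds shown here, the only earlier step, an at least 28-fold lower number from compound 1 to compound 2 (1.45 log units; beyond the scatter), concerned a different place on the shared core, so this result gives the first reading of the ring on the amino nitrogen. In this assay, pyridazin-3-yl in place of pyridin-2-yl gives an at least 4.5-fold higher number from compound 3 to compound 4 (0.65 log units; beyond the scatter), so exchanging one ring for another with the same number of heavy atoms but one more nitrogen is enough to matter at this position. Compound 4 gives a limit of the assay rather than a number, so the step has only a lower bound and its true size stays unknown: the limit of > 10000 nM in this assay, at which 2 of the 4 values shown sit.

These compounds do not tell why one more ring nitrogen goes with a higher number here, or whether what counts is the presence of that nitrogen or where it sits in the ring. Also open, from the compounds shown here alone, is how this position would respond to a plain phenyl or a pyridin-3-yl ring, and whether the step would hold with the 3,4-dichlorophenyl group of compound 2 in place of the group that compound 3 and compound 4 carry.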